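Sulfonamide nitrogen substitution in the aortic series

The source may hold more compounds than are shown below. What is called first, only, known or untested is meant among the compounds shown, and "the series" means these compounds.

The series rests on the core of compound 1 `CC1(C)C=C(n2ccccc2=O)c2cc(S(N)(=O)=O)ccc2O1`, which in a functional assay on the whole organism (aorta) with Rattus norvegicus as the target (a higher number here means a larger maximal response, a lower number a smaller maximal response), gives 77.5%. Compound 2 `CNS(=O)(=O)c1ccc2c(c1)C(n1ccccc1=O)=CC(C)(C)O2` carries a methyl on the sulfonamide nitrogen, and in this assay compound 2 gives 85.8%; it sits alongside compound 1, the step of a number 8.3 percentage points higher from compound 1 to compound 2 (within the scatter) lying within the scatter. Compound 3 `CC1(C)C=C(n2ccccc2=O)c2cc(S(=O)(=O)Nc3ccc([N+](=O)[O-])cc3)ccc2O1` is yet to be measured and differs from compound 2 by 4-nitrophenyl in place of methyl on a sulfonamide nitrogen. Going by the values given here, the one measured step, a number 8.3 percentage points higher from compound 1 to compound 2 (within the scatter), touches the same sulfonamide nitrogen but exchanges hydrogen for methyl, a far smaller change than the present one; it gives no guide to the 4-nitrophenyl. With nothing that bears directly on this change, no shift beyond the scatter is assumed and the range is kept wide. For compound 3 the estimated step is a number 5.8 percentage points lower from compound 2 to compound 3 (within the scatter). Compound 3 is therefore expected to give 80%, within 55% to 100%.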

Compound 3, largest response reached (Emax), in percent of the reference or control that the assay uses: 82.2%
Beside the measured number, compound 3's estimate is 2.2 percentage points below it; measured number inside the range.
By their numbers in this assay, from the lowest: compounds 1, 3 and 2 (each within the scatter of the next).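

On the sulfonamide nitrogen, going from methyl to the much larger 4-nitrophenyl, with its six-membered aromatic ring, gives a number 3.6 percentage points lower from compound 2 to compound 3 (within the scatter) in this assay, so even this large exchange produces no shift beyond the scatter. Set against the unsubstituted sulfonamide, the same group gives a number 4.7 percentage points higher from compound 1 to compound 3 (within the scatter), which places hydrogen, methyl and 4-nitrophenyl within the scatter of one another at this position. No measurement at hand accounts for this flat picture.

Still open, on these data alone, is whether plain phenyl, a carboxylic acid or a longer alkyl chain on this nitrogen would also stay within the same narrow band of maximal response. Also open, as far as these compounds go, is whether a second methyl on the same nitrogen, or an amine in place of the nitro group on the phenyl ring, would move the response beyond the scatter.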